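From Hydroxymethyl to an Acrylate Ester on the Shared Core

The source may hold more compounds than are shown below. What is called first, only, known or untested is meant among the compounds shown, and "the series" means these compounds.

Compound 1 `CC(C)OC(=O)c1ccc(-c2nn(Cc3ccccc3)c3ccccc23)cc1` and compound 2 `OCc1ccc(-c2nn(Cc3ccccc3)c3ccccc23)cc1` share one core and differ only in a group on an aromatic carbon. In a functional assay on cells (Platelet, Homo sapiens) for inhibition (on this read-out higher numbers stand for weaker inhibition and lower numbers for stronger inhibition), compound 1 reaches only the limit of the assay, > 10000 nM. Compound 2 likewise reaches only the limit, > 10000 nM. The step that the two limits leave unreadable from compound 1 to compound 2 cannot be read, as the limit of > 10000 nM in this assay, at which 2 of the 2 values shown sit, shows. Compound 2 thus stands at the limit of the assay, and no number places it among the others. Compound 3 `CCOC(=O)/C=C/c1ccc(-c2nn(Cc3ccccc3)c3ccccc23)cc1` carries the change (2-(ethoxycarbonyl)ethenyl in place of hydroxymethyl on an aromatic carbon). Within the data shown here, no measured step bears on this change except a step that the two limits leave unreadable from compound 1 to compound 2, which gives no size. Because of the limit of > 10000 nM in this assay, at which 2 of the 2 values shown sit, the expected step is a step that the limit leaves unreadable from compound 2 to compound 3, and the result is expected most likely to end at a limit once more. Compound 3 is expected to give about 15000 nM, in a range from 3000 nM to 60000 nM.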

Compound 3, half-maximal inhibitory concentration: > 10000 nM
Compound 3 was reported as a limit (the forecaster's own chance of this, stated with the estimate: 70%); the middle value lies beyond the limit too.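

No step among compound 1, compound 2 and compound 3 can be read in this assay, as all three are reported only as limits: the limit of > 10000 nM in this assay, at which 3 of the 3 values shown sit.

The compounds shown leave open how strongly each inhibits and whether any other group at this place on the shared core would give a readable value in this assay.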